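Swapping pyridin-4-yl for quinolin-3-yl on compound 3

A few compounds are considered here, and "the series" means these few. Any claim that something is new, unique, unknown or untested is made for them only; others in the source may bear on it.

Measured so far in a physicochemical assay for solubility, in phosphate buffer, at pH 7.4; a lower number here means a less soluble compound, a higher number a more soluble compound
- Compound 1 (`c1ccc2nc(N3CC(Oc4nccnc4N4CCCCC4)C3)ccc2c1`) gives < 1000 nM (a limit of the assay)
- Compound 2 (`NC(=O)C1CCN(c2nccnc2OC2CN(c3ccc4ccccc4n3)C2)CC1`) gives 14000 nM
- Compound 3 (`c1ccc2nc(N3CC(Oc4nccnc4-c4ccncc4)C3)ccc2c1`) gives 56000 nM

For the measured compounds named here, compound 3 has the highest number so far, as a 4.0-fold higher number from compound 2 to compound 3 (0.60 log units; beyond the scatter) and an at least 56-fold higher number from compound 1 to compound 3 (1.74 log units; beyond the scatter) show. The value of compound 1 (< 1000 nM) is a limit of the assay, not a number. Compound 4 (`c1ccc2ncc(-c3nccnc3OC3CN(c4ccc5ccccc5n4)C3)cc2c1`) has quinolin-3-yl in place of pyridin-4-yl on an aromatic carbon. Both steps changed this same place, and both lie beyond the scatter. Read in reverse, each loses pyridin-4-yl and ends at a lower number, though neither brings in quinolin-3-yl. A downward step in this assay is therefore expected, sized between those two. The estimated step is a 9.3-fold lower number from compound 3 to compound 4 (0.97 log units; beyond the scatter) (an expectation only). Compound 4 is estimated at 6000 nM (expected range 1200 nM to 25000 nM).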

Compound 4, solubility: < 1000 nM
Compound 4 was reported as a limit; the forecaster's own chance of this, stated with the estimate: 20%; at least 6.0-fold (0.77 log units) between middle value and limit.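

At this place, next to the ring nitrogen, carrying an aromatic ring does not by itself keep the number high: in this assay, replacing pyridin-4-yl with quinolin-3-yl gives an at least 56-fold lower number from compound 3 to compound 4 (1.74 log units; beyond the scatter). The same group in place of 4-carbamoylpiperidin-1-yl gives an at least 14-fold lower number from compound 2 to compound 4 (1.14 log units; beyond the scatter). Compound 4 and compound 1 each stand at a limit of the assay, not a number, so the step between them cannot be read: the limit of < 1000 nM in this assay, at which 2 of the 4 values shown sit.

Still open, from the compounds shown here alone, is how far compound 4 truly lies from compound 3. Also open, going by these compounds, is whether the added carbon-only aromatic ring alone accounts for the drop, something a naphthyl or phenyl group at this place would help to test.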